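Ring Size of the Acetylated Amide Substituent

The compounds below may be only part of what the source reports. "The series", "measured", "known", "first", "only" and "open" are said of these compounds alone.

Compound 1 `CN1CCC(NC(=O)c2ccncc2Nc2cc(-c3ccc4ccn(C)c4c3)c3nccnc3c2)CC1` gives 19500 nM in an assay on lysate for inhibition of 6-phosphofructo-2-kinase/fructose-2,6-bisphosphatase 3 (Homo sapiens), with stated times of 0.5 min and 45 min; on this read-out higher numbers stand for weaker inhibition and lower numbers for stronger inhibition.
Compound 2 `CC(=O)N1CC(NC(=O)c2ccncc2Nc2cc(-c3ccc4ccn(C)c4c3)c3nccnc3c2)C1` gives 97400 nM in this assay.

Among the compounds with values here, compound 2 holds the higher of the two numbers in this assay, and the only measured step, a 5.0-fold higher number from compound 1 to compound 2 (0.70 log units; beyond the scatter), is the one that bears on it. Compound 3 `CC(=O)N1CCC(NC(=O)c2ccncc2Nc2cc(-c3ccc4ccn(C)c4c3)c3nccnc3c2)C1` differs from compound 2 by 1-acetylpyrrolidin-3-yl in place of 1-acetylazetidin-3-yl on an amide-type nitrogen. That earlier step altered both the ring and the group on its nitrogen; here only the ring changes from four-membered to five-membered, so a smaller shift is expected, if anything toward compound 1. Compound 3 is therefore estimated at 60000 nM, between 20000 nM and 150000 nM. This corresponds to an expected 1.6-fold lower number from compound 2 to compound 3 (0.21 log units; within the scatter).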

Compound 3, half-maximal inhibitory concentration: > 100000 nM
Compound 3: a limit, no number; the forecaster's own chance of this, stated with the estimate: 15%; at least 1.6-fold (0.22 log units) between middle value and limit.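

In this assay compound 3 gives a limit of the assay, not a number: the limit of > 100000 nM in this assay, at which 1 of the 3 values shown sits. Going from the four-membered to the five-membered acetylated ring brought no readable move back toward compound 1: the result is an at least 1.0-fold higher number from compound 2 to compound 3 (0.01 log units; that floor lies within the scatter), so the two cannot be put in order. The 1-acetylpyrrolidin-3-yl group also stays on the weaker side of 1-methylpiperidin-4-yl, with an at least 5.1-fold higher number from compound 1 to compound 3 (0.70 log units; beyond the scatter).

On these data alone, it remains open whether the acetyl group or the ring accounts for this difference. A 1-acetylpiperidin-4-yl or 1-methylpyrrolidin-3-yl group on the amide-type nitrogen would separate the two.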